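Swapping the Anilino Ring on a Weakly Active Core

The source may report more compounds than this note shows. Statements on the series, on what has been measured and on what is new or still open speak of the compounds shown alone.

Compound 2 `COc1ccc(Nc2nc(SCc3cn(CC(=O)NC(=O)Nc4ccccn4)nn3)nc(-c3ccc(C(C)C)cc3)c2C#N)cc1` was tested in a functional assay on MCF7 cells (Homo sapiens) for inhibition, read by MTT assay, with a stated time of 72 h; on this read-out lower numbers stand for stronger inhibition and higher numbers for weaker inhibition. In this assay compound 2 gives only a limit, > 64000 nM, so its true number is not known. Compound 1 `CC(C)c1ccc(-c2nc(SCc3cn(CC(=O)NC(=O)Nc4ccccn4)nn3)nc(Nc3cccc([N+](=O)[O-])c3)c2C#N)cc1` gives 25900 nM in this assay. Among the measured compounds shown here, the one measured step, an at least 2.4-fold higher number from compound 1 to compound 2 (0.39 log units; beyond the scatter), therefore already runs into (the limit of > 64000 nM in this assay, at which 1 of the 2 values shown sits). Compound 3 `Cc1ccccc1Nc1nc(SCc2cn(CC(=O)NC(=O)Nc3ccccn3)nn2)nc(-c2ccc(C(C)C)cc2)c1C#N` differs from compound 2 by 2-methylphenyl in place of 4-methoxyphenyl on a nitrogen on an aromatic ring. For the measured compounds named here, no measured step compares two groups of this kind, so the only guide is that compound 2 already sits at the limit and that an at least 2.4-fold higher number from compound 1 to compound 2 (0.39 log units; beyond the scatter) went toward weaker inhibition. Compound 3 is expected to stay in the same weak region, with the step of an at least 1.0-fold lower number from compound 2 to compound 3 (0.02 log units; that floor lies within the scatter) expected to be small in either direction. The estimate for compound 3 is 60000 nM, between 20000 nM and 200000 nM, with a fair chance that this assay again reports only a limit.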

Compound 3, half-maximal inhibitory concentration: > 64000 nM
Compound 3 gave a limit, no number; the forecaster's own chance of this, stated with the estimate: 55%; middle value at least 1.0-fold (0.02 log units) from the limit.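

The change from 3-nitrophenyl to 2-methylphenyl on this nitrogen gives an at least 2.4-fold higher number from compound 1 to compound 3 (0.39 log units; beyond the scatter) in this assay, so a second replacement for the 3-nitrophenyl also moves toward weaker inhibition. Of the three compounds, only compound 1 gives a number, while the 4-methoxyphenyl of compound 2 and the 2-methylphenyl of compound 3 both end at a limit. The step from compound 2 to compound 3 cannot be read, because both values are limits: the limit of > 64000 nM in this assay, at which 2 of the 3 values shown sit.

Going by these compounds, it remains open whether the nitro group itself or its place on the ring sets compound 1 apart from the other two. Also open, on these data alone, is whether a phenyl ring carrying an amine or a carboxylic acid on this nitrogen would give a measurable number, and how it would compare with compound 1 at 25900 nM.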